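A few compounds are considered here, and "the series" means these few. Any claim that something is new, unique, unknown or untested is made for them only; others in the source may bear on it.

Measured in a functional assay on HEY cells (Homo sapiens) for cytotoxicity, read by MTT assay, with a stated time of 72 h; on this read-out lower numbers stand for stronger inhibition and higher numbers for weaker inhibition:
- compound 1 `N[C@H]1CC[C@H](Nc2c(C(=O)NCc3ccco3)nc(Br)c3cccnc23)CC1`: > 10000 nM
- compound 2 `COc1cccc(CNC(=O)c2nc(Br)c3cccnc3c2N[C@H]2CC[C@H](N)CC2)c1`: 7000 nM
- compound 3 `N[C@H]1CC[C@H](Nc2c(C(=O)NCc3ccc(Cl)cc3Cl)nc(Br)c3cccnc23)CC1`: 5000 nM

The entry for compound 1, > 10000 nM, is a limit of the assay and not a number.

Among the compounds with values here, compound 3 gives 5000 nM, and the only other number in the set cannot be told apart from it: a 1.4-fold lower number from compound 2 to compound 3 (0.15 log units; within the scatter).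

Compound 4 `C[C@H](NC(=O)c1nc(Br)c2cccnc2c1N[C@H]1CC[C@H](N)CC1)c1ccc(F)cc1` keeps the shared core and alters only the group on the amide-type nitrogen: 1-(4-fluorophenyl)ethyl in place of 2,4-dichlorobenzyl on an amide-type nitrogen. In short, 1-(4-fluorophenyl)ethyl stands in place of 2,4-dichlorobenzyl. Within the data shown here, none of the measured compounds carries this new group, so the evidence is indirect.

Three measured steps exchange the ring on the saturated chain carbon bound to that nitrogen. Two start from the limit and give only floors, both within the scatter: an at least 1.4-fold lower number from compound 1 to compound 2 (0.15 log units; that floor lies within the scatter), and an at least 2.0-fold lower number from compound 1 to compound 3 (0.30 log units; that floor lies within the scatter). Among the measured compounds shown here, the one step between two numbers is the small one already given, a 1.4-fold lower number from compound 2 to compound 3 (0.15 log units; within the scatter).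

On that precedent, no step beyond the scatter is expected in this assay, and no direction can be favoured with confidence. The estimated step is a 1.2-fold higher number from compound 3 to compound 4 (0.08 log units; within the scatter).

In this assay the estimate for compound 4 is 6000 nM, with an expected range of 2500 nM to 14000 nM.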

Compound 4, half-maximal inhibitory concentration: > 10000 nM
Compound 4 gave a limit, no number; the forecaster's own chance of this, stated with the estimate: 25%; middle value at least 1.6-fold (0.22 log units) from the limit.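

In this assay, within the data shown here, compound 4 gives > 10000 nM, which is a limit of the assay and not a number, so 1-(4-fluorophenyl)ethyl, the first group here with a defined stereocentre, yields no readable value at this amide-type nitrogen. The two steps that can be read are floors only, an at least 2.0-fold higher number from compound 3 to compound 4 (0.30 log units; that floor lies within the scatter) and an at least 1.4-fold higher number from compound 2 to compound 4 (0.15 log units; that floor lies within the scatter), and neither establishes a change beyond the scatter, while the step involving compound 1 cannot be read. Readable values at this position now come only from compound 2 and compound 3, and the other two compounds stop at the same limit: the limit of > 10000 nM in this assay, at which 2 of the 4 values shown sit.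

Compound 4 differs from compound 3 both in the ring substituents and at the chain carbon bound to the nitrogen, so the compounds shown do not separate these two changes; 4-fluorobenzyl or 1-(2,4-dichlorophenyl)ethyl on the same nitrogen would do so. Also open, as far as these compounds go, are how the other stereoisomer of 1-(4-fluorophenyl)ethyl would read here, and whether a benzyl group carrying a carboxylic acid or an amine would give a number in this assay.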